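A few compounds are considered here, and "the series" means these few. Any claim that something is new, unique, unknown or untested is made for them only; others in the source may bear on it.

Compound 1, `COc1ccc(C#N)cc1CSc1nc2cc(NC(=O)C3CC3)ccc2n1C(C)C`, reaches in an assay on isolated protein for inhibition of Gonadotropin-releasing hormone receptor (Rattus norvegicus) (on this read-out higher numbers stand for weaker inhibition and lower numbers for stronger inhibition), only a limit, > 10000 nM, rather than a number. Compound 2, `CCn1c(SCc2cc([N+](=O)[O-])ccc2OC)nc2cc(NC(=O)NC(C)(C)C)ccc21`, gives in this assay a value of 170 nM, which is the only actual number among the two results shown. Compound 3, `CCCCCn1c(SCc2cc([N+](=O)[O-])ccc2OC)nc2cc(NC(=O)NC(C)(C)C)ccc21`, has not yet been tested; it differs from compound 2 by propyl in place of hydrogen on a saturated chain carbon, two bonds along the chain from an aromatic nitrogen. Going by the values given here, no measured pair shows the effect of this one change on its own, and compound 1, which sits at the limit described by the limit of > 10000 nM in this assay, at which 1 of the 2 values shown sits, differs from compound 2 in several places at once and cannot serve as a guide. The step from compound 2 to compound 3 is expected to be modest, a 1.8-fold higher number from compound 2 to compound 3 (0.25 log units; within the scatter), with a slight lean toward weaker inhibition. Compound 3 is estimated at 300 nM, within a range from 80 nM to 1500 nM.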

Compound 3, half-maximal inhibitory concentration: 880 nM
Compound 3: middle estimate off by 2.9-fold (0.47 log units), on the low side; the range from low to high includes it.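

Going by these compounds alone, compound 2 and compound 3 form the first measured pair that differs in only one place: replacing ethyl with pentyl gives a 5.2-fold higher number from compound 2 to compound 3 (0.71 log units; beyond the scatter) in this assay. This shows that inhibition in this assay responds to the change at this position, as the step lies beyond the scatter. The longer chain weakens inhibition without removing it, as compound 3 still gives an actual number rather than a limit, although nothing shown here accounts for the loss.

As far as these compounds go, with only ethyl and pentyl compared on this core, it remains open whether inhibition falls steadily with chain length or drops at one particular length. It is also unknown how a smaller methyl group, an intermediate butyl chain or a chain ending in an amine would behave at this position.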